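Solubility of compound 4 after swapping the tetrazole

This account rests on a few compounds, and the source may have more. Where it says the series, first, only, none or still open, it means among the compounds named here.

Three compounds share a core, each measured in a physicochemical assay for solubility, at pH 6; a lower number here means a less soluble compound, a higher number a more soluble compound. Compound 1 `N#Cc1ccc(-c2cc(-c3ccc(C(N)=O)cc3)cc(-c3cncs3)n2)cc1` gives 64000 nM. Compound 2 `c1coc(-c2cc(-c3nccs3)cc(-c3ccc(-c4nccs4)cc3)n2)c1` reports only a limit, < 1000 nM, which is the limit of < 1000 nM in this assay, at which 1 of the 3 values shown sits. Compound 3 `N#Cc1ccc(-c2cc(-c3ccc(-c4nnn[nH]4)cc3)cc(-c3ccco3)n2)cc1` gives 18000 nM, the lowest of the two numbers shown; compound 1 sits a gap above it that lies beyond the scatter. The remaining value is the limit of compound 2.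

Compound 4 `N#Cc1ccc(-c2cc(-c3ccc(C(=O)NN)cc3)cc(-c3ccco3)n2)cc1` differs from compound 3 in one place: aminocarbamoyl in place of 1H-tetrazol-5-yl on an aromatic carbon. For the measured compounds named here, no two measured compounds differ in a single spot, so no measured step guides the change. The data give no cause for either direction. Compound 3's number is already low, and compound 1, carrying a related amide-type group, sits higher, so the step from compound 3 to compound 4 is expected to be small, within the scatter or a slight rise, as a 1.2-fold higher number from compound 3 to compound 4 (0.09 log units; within the scatter). Compound 4 is estimated at 22000 nM in this assay, with a range from 5000 nM to 80000 nM.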

Compound 4, solubility: 500000 nM
The estimate for compound 4 lay 23-fold (1.36 log units) below the measured number, outside the stated range (above it).
By their numbers in this assay, from the lowest: compound 3; then compound 1; then compound 4. At a limit, below all of these: compound 2.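

For the compounds shown here, at this place, on an aromatic carbon of a six-membered aromatic ring of carbon only, para to a large group, the earlier compounds offered no comparison in a single spot. Aminocarbamoyl in place of 1H-tetrazol-5-yl now provides one, and in this assay it gives a 28-fold higher number from compound 3 to compound 4 (1.44 log units; beyond the scatter). This shows that a change at this one place, with the rest of the structure held fixed, can produce a large step in this read-out, but nothing shown accounts for its size.

The compounds shown leave open how a carboxylic acid or an aminomethyl group at this place would read in this assay. They also leave open whether the same swap gives a step of this size when the other groups on the shared core differ.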